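The source may hold more compounds than are shown below. What is called first, only, known or untested is meant among the compounds shown, and "the series" means these compounds.

In a functional assay on MCF-10A cells (Homo sapiens) for antiproliferative activity, with a stated time of 48 h (on this read-out higher numbers stand for an effect only at larger amounts of compound and lower numbers for an effect already at smaller amounts), compound 1 `COc1ccc2nc(C)cc(NCc3ccccc3OC)c2c1` gives 25200 nM, compound 2 `Cc1cc(NCc2ccc(F)cc2)c2ccccc2n1` gives 15400 nM and compound 3 `CCCCCCOc1ccc2nc(C)cc(NCc3ccc(F)cc3)c2c1` gives 8800 nM. Compound 3 thus has the lowest number of the three, although it lies within the scatter of compound 2 and is clearly separated only from compound 1. Compound 4 `CCCCCCCCCCOc1ccc2nc(C)cc(NCc3ccc(F)cc3)c2c1` differs from compound 3 by butyl in place of hydrogen on a saturated chain carbon, six bonds along the chain from an oxygen on an aromatic ring, which lengthens the chain already present. For the measured compounds named here, one measured step bears on this change: a 1.8-fold lower number from compound 2 to compound 3 (0.24 log units; within the scatter), where hexyloxy takes the place of hydrogen on an aromatic carbon. Going by the values given here, that step introduces the chain rather than extending it, and no measured pair shows what extension does. Among the compounds with values here, since the only related step stays within the scatter, no large change is predicted in this assay, and the direction remains uncertain. The expected change is a 1.3-fold lower number from compound 3 to compound 4 (0.10 log units; within the scatter), which would not exceed the scatter. For compound 4 the estimated value is 7000 nM, with an expected range from 2500 nM to 20000 nM.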

Compound 4, half-maximal effective concentration: 1900 nM
Compound 4: middle estimate off by 3.7-fold (0.57 log units), on the high side, and the stated range ends above it.
By their numbers in this assay, from the lowest: compound 4; then compounds 3, 2 and 1 (each within the scatter of the next, the first and the last beyond it).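

In this assay, butyl in place of hydrogen on the saturated chain carbon, six bonds along the chain from the oxygen on the aromatic ring, gives a 4.6-fold lower number from compound 3 to compound 4 (0.67 log units; beyond the scatter) and so moves the number beyond the scatter. The earlier step, a 1.8-fold lower number from compound 2 to compound 3 (0.24 log units; within the scatter), stayed within the scatter, so only this extension shows that the outer part of the chain can change the read-out. No available evidence accounts for this change.

The compounds shown leave open whether the number falls gradually with chain length or only once the chain reaches its present extent, and whether a longer chain would lower it further. They also leave open whether an amine or a carboxylic acid at the end of the chain would keep this effect.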